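Two ester-linked analogues and a thiophene-bearing variant

A few compounds are considered here, and "the series" means these few. Any claim that something is new, unique, unknown or untested is made for them only; others in the source may bear on it.

The series rests on a shared core, seen in compound 1 `C=C1CC[C@@H]2[C@](C)(CO)[C@H](O)CC[C@@]2(C)[C@@H]1CC(Sc1ccccn1)C1=CCOC1=O` and compound 2 `C=C1CC[C@@H]2[C@](C)(CO)[C@H](O)CC[C@@]2(C)[C@@H]1C/C=C1/C(=O)OC[C@H]1OC(=O)CSc1ccc([N+](=O)[O-])cc1`. In a functional assay on PC-3 cells (Homo sapiens) for inhibition, read by MTT assay, with a stated time of 48 h (on this read-out higher numbers stand for weaker inhibition and lower numbers for stronger inhibition), compound 1 gives 18000 nM. In this assay compound 2 gives 17000 nM, and this number sits within the scatter of the number for compound 1, so the two measured compounds mark one common level rather than an order. Compound 3 `C=C1CC[C@@H]2[C@](C)(CO)[C@H](O)CC[C@@]2(C)[C@@H]1C/C=C1/C(=O)OC[C@H]1OC(=O)CCCSc1cccs1` differs from compound 2 in one place: 2-((thiophen-2-yl)sulfanyl)ethyl in place of (4-nitrophenyl)sulfanyl on a saturated chain carbon bound to a carbonyl carbon. Among the compounds with values here, no measured pair in the set shows a step of this kind, so nothing measured tells how far a change on the saturated chain carbon bound to the carbonyl carbon can move the read-out. The two measured numbers suggest that the part beyond the ester carbonyl leaves the read-out near a common level, and on that basis compound 3 is expected to show a step from compound 2 of a 1.1-fold lower number from compound 2 to compound 3 (0.05 log units; within the scatter), which would be no change beyond the scatter. Compound 3 is therefore estimated at 15000 nM, with a range from 5000 nM to 45000 nM.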

Compound 3, half-maximal inhibitory concentration: 16000 nM
For compound 3 the middle estimate is 1.1-fold (0.03 log units) below the measured one; measured number inside the range.
By their numbers in this assay, from the lowest: compounds 3, 2 and 1 (each within the scatter of the next).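

The exchange of (4-nitrophenyl)sulfanyl for 2-((thiophen-2-yl)sulfanyl)ethyl on a saturated chain carbon bound to a carbonyl carbon gives the first step measured at this place, a 1.1-fold lower number from compound 2 to compound 3 (0.03 log units; within the scatter), in this assay. Within the data shown here, it shows that this single change, which takes away the six-membered aromatic ring of carbon only and brings in a five-membered aromatic ring with 1 hetero atom, leaves the read-out at the level already shared by the earlier compounds, so the nitro group and the six-membered ring are not needed to hold that level. No measurement among the data given bears on why the number stays where it does.

Since the only step at this place lies within the scatter, the compounds shown do not tell whether any group there can move the read-out at all, or whether the level would hold without an aromatic ring or a sulfur atom. On these data alone, a primary amine or a carboxylic acid at the end of the chain, or a plain alkyl chain, is not among them, so the reach of this position remains open.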